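This account rests on a few compounds, and the source may have more. Where it says the series, first, only, none or still open, it means among the compounds named here.

Compound 1, `O=C(CN(c1ncnc2c1ncn2C1CCCCO1)C1CC1)N[C@@H](CCC(=O)OCc1ccccc1)C(=O)OCc1ccccc1`, is the stronger of the two compounds measured in a functional assay on the whole organism (Tail, strain ICR) with Mus musculus as the target, in the tail flick test, with a stated time of 120 min, at a dose of 25 umol/kg by the oral route; on this read-out higher numbers stand for a stronger effect at the one dose given and lower numbers for a weaker effect: compound 1 gives 20.7%. Compound 2, `CSCC[C@H](NC(=O)CN(c1nc(Cl)nc2[nH]cnc12)C1CC1)C(=O)O`, shares neither the same core nor the same ester, and in this assay compound 2 gives 5.67%, a gap to compound 1 that lies beyond the usual scatter. Compound 3, `CSCC[C@H](NC(=O)CN(c1ncnc2c1ncn2C1CCCCO1)C1CC1)C(=O)OCc1ccccc1`, keeps the core and the benzyl ester of compound 1 but carries a different side chain: methylsulfanyl in place of benzyloxycarbonyl on a saturated chain carbon, three bonds along the chain from an amide-type nitrogen and a carbonyl carbon. Among the compounds with values here, no measured pair shows this exact change, so its size is unknown. Within the data shown here, because compound 2, the only compound bearing methylsulfanyl, gives 5.67%, a small downward step from compound 1 to compound 3 is expected, a number 6.7 percentage points lower from compound 1 to compound 3 (within the scatter), though this may well fall within the scatter. Compound 3 is therefore estimated to give 14%, with a range from 3% to 28% in this assay.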

Compound 3, a percentage reported as activity, at one dose (the size of the read-out at that dose, not a potency): 28.7%
Estimate against measurement, compound 3: 14.7 percentage points below; the measured number lies above the stated range.
By their numbers in this assay, from the lowest: compound 2; then compounds 1 and 3 (each within the scatter of the next).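

In this assay, putting methylsulfanyl in place of benzyloxycarbonyl on a saturated chain carbon, three bonds along the chain from an amide-type nitrogen and a carbonyl carbon, gives a number 8 percentage points higher from compound 1 to compound 3 (within the scatter). This pair therefore shows that the group at this place can lose its six-membered aromatic ring and shrink from 10 heavy atoms to 2 without the read-out moving beyond the scatter, at this one dose and time. Nothing shown here explains why two such different groups read alike.

The compounds shown leave open whether a carboxylic acid or an amine at this same place would also keep the read-out. They also leave open whether a longer chain carrying methylsulfanyl would do so, and whether the likeness of the pair holds at other doses.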